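This account rests on a few compounds, and the source may have more. Where it says the series, first, only, none or still open, it means among the compounds named here.

For the measured compounds named here, compound 2, `O=[N+]([O-])c1cc(-c2nnn(Cc3ccc(F)cc3)n2)cc([N+](=O)[O-])c1`, is one of two compounds measured in an ADME assay on CHO-K1 cells (Cricetulus griseus) for cytotoxicity, read by MTT assay, with a stated time of 24 h; on this read-out lower numbers stand for stronger inhibition and higher numbers for weaker inhibition. In this assay compound 2 gives 35000 nM, the lowest of the two numbers shown. Going by the values given here, its only neighbour, compound 1, `O=[N+]([O-])c1cc(-c2nnn(Cc3cccc(F)c3)n2)cc([N+](=O)[O-])c1`, gives 315000 nM in this assay; the step of a 9.0-fold lower number from compound 1 to compound 2 (0.95 log units; beyond the scatter) is the only measured step, and it came from moving a fluoro group from one position of the phenyl ring to another.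

Compound 3, `COc1ccc(Cn2nnc(-c3cc([N+](=O)[O-])cc([N+](=O)[O-])c3)n2)cc1`, carries a different change: methoxy in place of fluoro on an aromatic carbon. Among the compounds with values here, no measured step covers a methoxy in place of a fluoro, so the one measured step of a 9.0-fold lower number from compound 1 to compound 2 (0.95 log units; beyond the scatter) cannot be carried over directly; it shows only that a small change on this phenyl ring can shift the number in this assay by a modest amount. In the absence of a matching step, the expected step of a 1.1-fold higher number from compound 2 to compound 3 (0.06 log units; within the scatter) is none beyond the scatter. Compound 3 is therefore estimated to give 40000 nM in this assay, with a range from 12000 nM to 130000 nM.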

Compound 3, half-maximal inhibitory concentration: 96000 nM
Estimate against measurement, compound 3: 2.4-fold (0.38 log units) below; measured number inside the range.
By their numbers in this assay, from the lowest: compound 2; then compound 3; then compound 1.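

In this assay, the earlier step only moved a fluoro group around the phenyl ring, whereas this result exchanges the group itself at the place para to a large group: methoxy in place of fluoro gives a 2.7-fold higher number from compound 2 to compound 3 (0.44 log units; beyond the scatter). So the group held at this place matters as well as where it sits, though the shift is modest. Measured against the 3-fluorophenyl compound, the 4-methoxyphenyl compound gives a 3.3-fold lower number from compound 1 to compound 3 (0.52 log units; beyond the scatter), which places it between the two fluoro compounds, with both of its gaps beyond the scatter; nothing shown explains why the numbers fall in this order.

For the compounds shown here, with only two groups at this place, no trend can be drawn, and it remains open how an amine, a carboxylic acid or a longer chain such as ethoxy would read here. A 3-methoxyphenyl compound would also be needed to tell whether methoxy responds to a change of ring position the way fluoro does, since the step between the two fluoro compounds cannot simply be assumed to carry over to another group.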